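Bromo to iodo: working notes on compound 4

A few compounds are considered here, and "the series" means these few. Any claim that something is new, unique, unknown or untested is made for them only; others in the source may bear on it.

Compound 1 `COc1ccc(-c2cc(=O)c3c(OC)cc(OC)cc3[nH]2)cc1` gives > 31100 nM in a functional assay on HepG2 cells (Homo sapiens) for antiproliferative activity, with a stated time of 72 h (a higher number here means that more compound is needed for the effect, a lower number that less compound is needed), a limit of the assay. Compound 2 `COc1ccc(-c2cc(=O)c3c(OC)cc(OC)cc3n2Cc2ccccc2)cc1` gives > 17300 nM in this assay, again a limit. Compound 3 `COc1ccc(-c2c(Br)c(=O)c3c(OC)cc(OC)cc3n2S(=O)(=O)c2ccc(OC)cc2)cc1` gives > 20000 nM in this assay, also a limit.

Going by the values given here, compound 3 thus sits at the limit of > 20000 nM in this assay, at which 1 of the 3 values shown sits, and every value shown is a limit; no compound shows a readable number. Among the compounds with values here, the only step between measured compounds, a step that the two limits leave unreadable from compound 1 to compound 2, is unreadable because both ends are limits.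

Compound 4 `COc1ccc(-c2c(I)c(=O)c3c(OC)cc(OC)cc3n2S(=O)(=O)c2ccc(OC)cc2)cc1` differs from compound 3 by iodo in place of bromo on an aromatic carbon. Within the data shown here, no measured step bears on a halogen exchange of this kind, so the size of a step that the limit leaves unreadable from compound 3 to compound 4 is expected to be not resolvable: compound 4 is estimated at 30000 nM, within 8000 nM to 100000 nM, most likely reported again as a limit.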

Compound 4, half-maximal effective concentration: > 17300 nM
Compound 4 was reported as a limit (the forecaster's own chance of this, stated with the estimate: 80%); the middle value lies beyond the limit too.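

Compound 3 and compound 4 are both reported as limits, and no step can be read between them. The compounds shown leave open whether iodo in place of bromo changes anything, and whether any compound gives a readable number in this assay.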